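Lipophilicity from isoxazole to pyrazole on a shared core

The source may hold more compounds than are shown below. What is called first, only, known or untested is meant among the compounds shown, and "the series" means these compounds.

Measured in a physicochemical assay for lipophilicity, at pH 7.4; a higher number here means a more lipophilic compound, a lower number a more polar compound:
- Compound 1 (`CC(C)Oc1ccc(-c2nnc(-c3ccno3)s2)cc1Cl`): 6.93
- Compound 2 (`Cc1nn(-c2nnc(-c3ccc(OC(C)C)c(Cl)c3)s2)c(C)c1CC(=O)O`): 3.62

Of these two compounds, compound 1 stands highest at 6.93. Compound 2 sits at 3.62, and that gap lies well beyond the usual scatter of repeated measurements.

The next compound to be measured is compound 3 (`CC(C)Oc1ccc(-c2nnc(-c3cn[nH]c3)s2)cc1Cl`). It keeps the core of compound 1 but carries 1H-pyrazol-4-yl in place of 1,2-oxazol-5-yl on an aromatic carbon. Both rings are five-membered and aromatic, with the same number of heavy atoms, but their counts of hydrogen-bond donors and acceptors differ.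

Going by the values given here, no measured pair of compounds differs in just one place, so no direct precedent exists for this swap. The expectation rests on the structural change alone and points to a moderate fall in this assay, probably beyond the scatter. The estimated change is a number 0.83 log units lower from compound 1 to compound 3 (beyond the scatter). For compound 3 the expected value is 6.1, with an estimated range from 5.3 to 6.8.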

Compound 3, distribution coefficient: 5
For compound 3 the middle estimate is 1.10 log units above the measured one; measured number outside the range, below it.
By their numbers in this assay, from the lowest: compound 2; then compound 3; then compound 1.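

In this assay, going by these compounds alone, this position now has its first comparison in which only one place changes: the swap gives a number 1.93 log units lower from compound 1 to compound 3 (beyond the scatter) and that is a large step. Replacing one five-membered aromatic ring with another of the same heavy-atom count is therefore far from a neutral exchange at this aromatic carbon, even though the two rings differ only in a few counted features: 1,2-oxazol-5-yl has 0 hydrogen-bond donors and 2 hydrogen-bond acceptors, while 1H-pyrazol-4-yl has 1 hydrogen-bond donor and 1 hydrogen-bond acceptor, and a ring nitrogen takes the place of the ring oxygen. Nothing measured here shows which of these differences accounts for the step.

This single pair cannot show whether a step of this size would recur on a different core, or whether it is particular to the core of compound 1. It also leaves open how this assay would respond at the same position to a group of another kind, such as an amine or a nitrile, in place of either ring.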